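Lengthening the Alkyl Chain of a Carbamate Series

The compounds below may be only part of what the source reports. "The series", "measured", "known", "first", "only" and "open" are said of these compounds alone.

Of the compounds shown here, three sharing one core have been tested in a functional assay on MCF7 cells (Homo sapiens) for cytotoxicity, read by MTT assay, with a stated time of 72 h; on this read-out lower numbers stand for stronger inhibition of growth and higher numbers for weaker inhibition of growth. Compound 1 `N#C[Se]c1ccc(NC(=O)OCc2ccccc2)cc1` gives 8700 nM. Compound 2 `N#C[Se]c1ccc(NC(=O)Oc2ccccc2)cc1` gives 4000 nM. Compound 3 `CC(C)COC(=O)Nc1ccc([Se]C#N)cc1` gives 18100 nM, the highest number of the three and so the weakest inhibition of growth among them. Both steps that lead to compound 3 point the same way: a 2.1-fold higher number from compound 1 to compound 3 (0.32 log units; beyond the scatter), and a 4.5-fold higher number from compound 2 to compound 3 (0.66 log units; beyond the scatter).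

Compound 4 `CCCCCCOC(=O)Nc1ccc([Se]C#N)cc1` is the next compound. It differs from compound 3 in one place: pentyl in place of isopropyl on a saturated chain carbon bound to an oxygen next to a carbonyl group. The two measured steps each replace phenyl with isopropyl or isobutyl, and in each case the number rose. The change to compound 4 is of a different kind, one alkyl chain giving way to a longer one, with no ring at either end. Within the data shown here, no measured pair shows a change of this kind, so its direction cannot be read from these data. The expected step of a 1.5-fold lower number from compound 3 to compound 4 (0.18 log units; within the scatter) is therefore small, within or near the scatter, in either direction. Compound 4 is expected to give about 12000 nM in this assay, with a likely range from 5000 nM to 30000 nM.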

Compound 4, concentration for 50% growth inhibition in the MCF7 assay: 6600 nM
The estimate for compound 4 lay 1.8-fold (0.26 log units) above the measured number; low and high end bracket the measured number.
By their numbers in the MCF7 assay, from the lowest: compounds 2, 4 and 1 (each within the scatter of the next, the first and the last beyond it); then compound 3.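

At this position, on a saturated chain carbon bound to an oxygen next to a carbonyl group, one alkyl chain replacing another can shift the result in the MCF7 assay, with a 2.7-fold lower number from compound 3 to compound 4 (0.44 log units; beyond the scatter). The rise seen on going from a ring to an alkyl group in compound 3 also does not hold for every alkyl group, since in the MCF7 assay compound 4 cannot be told apart from either ring-bearing compound, with a 1.7-fold higher number from compound 2 to compound 4 (0.22 log units; within the scatter) and a 1.3-fold lower number from compound 1 to compound 4 (0.12 log units; within the scatter). In a physicochemical assay, with a stated time of 180 min, tested at 0.5 mg/mL (on this read-out higher numbers stand for more inhibition at the one concentration tested (going by the name of the read-out) and lower numbers for less inhibition), compound 3 gives 27.1%. In the physicochemical assay compound 4 gives > 25%, which is a limit of the assay, so the step to it cannot be read: the limit of > 25% in the physicochemical assay, at which 1 of the 2 values shown sits.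

Among these compounds, the one step between alkyl groups changes both chain length and branching, so the effect of each alone stays unknown, and a straight butyl chain or a branched hexyl chain would help to separate them. Also open, as far as these compounds go, is what a longer chain such as decyl, or an amine or a carboxylic acid at the end of the chain, would do to the number in the MCF7 assay.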